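A few compounds are considered here, and "the series" means these few. Any claim that something is new, unique, unknown or untested is made for them only; others in the source may bear on it.

Of the compounds shown here, three sharing one core have been measured in an ADME assay on microsomes from liver (Homo sapiens) for metabolic stability, with a stated time of 10 min; a lower number here means that less of the compound is left, a higher number that more of the compound is left. Compound 1 `CC(C)(C)NC(=O)NCCS(=O)(=O)NC(=O)c1ccc(Nc2nc(NC3(c4ccc(Cl)cc4)CC3)nc(OCC(F)(F)F)n2)cc1` gives 96%. Compound 2 `CC(C)OC(=O)NCCS(=O)(=O)NC(=O)c1ccc(Nc2nc(NC3(c4ccc(Cl)cc4)CC3)nc(OCC(F)(F)F)n2)cc1` gives 100%. Compound 3 `CS(=O)(=O)NC(=O)c1ccc(Nc2nc(NC3(c4ccc(Cl)cc4)CC3)nc(OCC(F)(F)F)n2)cc1` gives 100%. Compound 3 thus stands level with compound 2 at the digits shown, the two together the highest of the three, and compound 1 lies a number 4 percentage points higher from compound 1 to compound 3 (within the scatter). The other two steps are of the same kind: a number 4 percentage points higher from compound 1 to compound 2 (within the scatter) and no change at the digits printed from compound 2 to compound 3 (within the scatter); all three lie within the scatter.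

Compound 4 `Cc1ccccc1S(=O)(=O)NC(=O)c1ccc(Nc2nc(NC3(c4ccc(Cl)cc4)CC3)nc(OCC(F)(F)F)n2)cc1` differs from compound 3 in one place: 2-methylphenyl in place of methyl on a sulfonyl sulfur. Within the data shown here, no measured step touches the group on the sulfonyl sulfur itself, so none bears on this change directly. What the three steps do show is that large changes on the chain carbon bound to that sulfur left this assay unmoved, and compound 3 already sits at the top of the scale. Compound 4 is therefore expected to stay close, with a step of a number 8 percentage points lower from compound 3 to compound 4 (within the scatter), giving an estimate of 92%, in the range 75% to 100%.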

Compound 4, percent of the compound remaining: 100%
Compound 4: the middle estimate sits 8 percentage points below what was measured, within the range that was stated.
By their numbers in this assay, from the lowest: compounds 1, 2, 3 and 4 (each within the scatter of the next).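

In this assay, among the compounds shown only compound 4 carries an aromatic ring on the sulfonyl sulfur, and exchanging methyl for 2-methylphenyl at this position gives no change at the digits printed from compound 3 to compound 4 (within the scatter). Measured against the two longer chains on that sulfur, the same ring gives no change at the digits printed from compound 2 to compound 4 (within the scatter) and a number 4 percentage points higher from compound 1 to compound 4 (within the scatter), so seven heavy atoms and a six-membered aromatic ring in place of a single carbon do not take the number outside the scatter of the other three compounds. Nothing available explains this reading.

From the compounds shown here alone, whether an amine or a carboxylic acid on the chain at the sulfonyl sulfur, or a phenyl ring without its methyl, would give a similar number remains open. Changes elsewhere on the shared core also remain open, as all four compounds differ only on the sulfonyl sulfur.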